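The compounds below may be only part of what the source reports. "The series", "measured", "known", "first", "only" and "open" are said of these compounds alone.

Of the compounds shown here, three have been measured so far in a functional assay on DU-145 cells (Homo sapiens) for inhibition, read by trypan blue exclusion, with a stated time of 96 h; on this read-out higher numbers stand for weaker inhibition of growth and lower numbers for stronger inhibition of growth. Compound 1 (`O=C(/C(=C\c1c(O)cc(O)cc1O)S(=O)(=O)c1ccccc1Br)c1ccc(Cl)cc1`) gives 50000 nM, and compound 2 (`Cc1ccc(CS(=O)(=O)/C(=C/c2cccc(Cl)c2Cl)C(=O)c2ccc(Cl)cc2)cc1`) gives 1000 nM. Compound 3 (`Cc1ccc(CS(=O)(=O)/C(=C/c2ccc(N(C)C)cc2)C(=O)c2ccc(Cl)cc2)cc1`) gives 50000 nM, level with compound 1, and together they hold the highest number of the three, so compound 3 stands at the weak end of this small set.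

Compound 4 (`Cc1ccc(CS(=O)(=O)/C(=C/c2c(O)cc(O)cc2O)C(=O)c2ccc(Cl)cc2)cc1`) keeps the rest of compound 3 and changes one group: 2,4,6-trihydroxyphenyl in place of 4-(dimethylamino)phenyl on a double-bonded chain carbon bound to a double-bonded chain carbon. Within the data shown here, only one measured step bears on this place, a 50-fold higher number from compound 2 to compound 3 (1.70 log units; beyond the scatter). This large step came with 4-(dimethylamino)phenyl in place of 2,3-dichlorophenyl, and it shows that a swap here can move the number a long way. It does not show what 2,4,6-trihydroxyphenyl will do. The nearest guide is compound 1, which carries that same group at this place, differs elsewhere in the molecule and gives 50000 nM. With that value as the guide, no step beyond the scatter is expected in this assay, and the expected change is a 1.7-fold lower number from compound 3 to compound 4 (0.22 log units; within the scatter). With so few compounds to go on, the range stays wide. For compound 4 the estimated value is 30000 nM, with an expected range from 5000 nM to 60000 nM.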

Compound 4, concentration for 50% growth inhibition: > 100000 nM
Compound 4 ended at the assay's limit (the forecaster's own chance of this, stated with the estimate: 25%); middle value at least 3.3-fold (0.52 log units) away from the limit.
By their numbers in this assay, from the lowest: compound 2; then compounds 1 and 3 (each within the scatter of the next). At a limit, above all of these: compound 4.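

In this assay compound 4 stands at a limit of the assay and not at a number: the limit of > 100000 nM in this assay, at which 1 of the 4 values shown sits. With the 4-methylbenzyl group on the sulfonyl sulfur kept, 2,3-dichlorophenyl on a double-bonded chain carbon bound to a double-bonded chain carbon now has two partners that sit far from it, since 2,4,6-trihydroxyphenyl gives an at least 100-fold higher number from compound 2 to compound 4 (2.00 log units; beyond the scatter), a large step beyond the scatter, as 4-(dimethylamino)phenyl did before it, so among the groups shown here only 2,3-dichlorophenyl goes with the low number. The other two readings are floors within the scatter, an at least 2.0-fold higher number from compound 3 to compound 4 (0.30 log units; that floor lies within the scatter) for the swap of one aromatic group for the other and an at least 2.0-fold higher number from compound 1 to compound 4 (0.30 log units; that floor lies within the scatter) for the change on the sulfonyl sulfur, so neither change is shown to matter, and neither is shown to do nothing.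

The compounds shown leave open how far compound 4 lies past the limit, and so the true size of all three steps. They also leave open what on the ring goes with the low number of compound 2: a phenyl ring with a single chlorine, or with methoxy groups in place of the hydroxyl groups, would bear on that.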